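Demethylation of a methoxy group on a bis-amidine benzofuran scaffold

A few compounds are considered here, and "the series" means these few. Any claim that something is new, unique, unknown or untested is made for them only; others in the source may bear on it.

Three compounds were measured in an ADME assay on L6 cells (Rattus norvegicus) for cytotoxicity; on this read-out lower numbers stand for stronger inhibition and higher numbers for weaker inhibition:

Compound 1 `COc1cc(C(=N)NC(C)C)ccc1-c1cc2cc(C(=N)NC(C)C)ccc2o1`: 98100 nM
Compound 2 `COc1cc(C2=NCCN2)ccc1-c1cc2cc(C3=NCCN3)ccc2o1`: 7400 nM
Compound 3 `CC(C)NC(=N)c1ccc(-c2cc3cc(C(=N)NC(C)C)ccc3o2)c(O)c1`: > 183000 nM

For compound 3 this assay reports only a limit, > 183000 nM, not a number. Compound 1 and compound 3 differ in one place: hydrogen in place of methyl on an oxygen on an aromatic ring. That change gave an at least 1.8-fold higher number from compound 1 to compound 3 (0.27 log units; that floor lies within the scatter), so it did not lower the number, and the floor of the step is too small to be read as a real difference. Compound 2 gives a lower number than compound 1, and that gap is beyond the usual scatter; the difference between the two cores is not broken down here.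

Compound 4 `Oc1cc(C2=NCCN2)ccc1-c1cc2cc(C3=NCCN3)ccc2o1` has not yet been measured. Going by the values given here, it differs from compound 2 by hydrogen in place of methyl on an oxygen on an aromatic ring, the same change as the one from compound 1 to compound 3, made at the same kind of place on the shared core. For compound 4 the expected step is a 1.6-fold higher number from compound 2 to compound 4 (0.21 log units; within the scatter), which rests on the observation that the same change gave an at least 1.8-fold higher number from compound 1 to compound 3 (0.27 log units; that floor lies within the scatter). Compound 4 is therefore expected to give roughly 12000 nM in this assay, most likely between 5000 nM and 40000 nM, a modest rise if anything.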

Compound 4, half-maximal inhibitory concentration: 150000 nM
Beside the measured number, compound 4's estimate is 13-fold (1.10 log units) below it, outside the stated range (above it).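

In this assay, replacing methoxy with hydroxy on the core of the imidazoline-free comparison was not the case here: on the core carrying the two ring-closed amidines, the same swap gave a 20-fold higher number from compound 2 to compound 4 (1.31 log units; beyond the scatter), a large move towards weaker inhibition. Going by these compounds, this shows that the change can raise the number sharply on one core and that it lowered the number on neither core, but it does not show that the size of the step carries over from one core to the other, or that it fails to: the same change on two cores in this assay, an at least 1.8-fold higher number (0.27 log units; that floor lies within the scatter) from compound 1 to compound 3 and a 20-fold higher number (1.31 log units; beyond the scatter) from compound 2 to compound 4; the limit leaves it open whether they differ Compound 3 has only a limit of the assay, > 183000 nM, not a number, so the true size of the step on the core with the two isopropyl amidines stays unknown.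

What the compounds shown leave open is whether the large step belongs to hydroxy itself or to the loss of the methyl, since no other group, such as an ethoxy, a longer chain or an amine, stands at that place on either core. They also leave open how a hydroxy compound on the isopropyl amidine core would read on a scale that reaches past its limit, which is what a real comparison between the two cores would need.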